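Amide to urea on a shared pyrazole-bearing scaffold

A few compounds are considered here, and "the series" means these few. Any claim that something is new, unique, unknown or untested is made for them only; others in the source may bear on it.

Compound 1 `COc1cc(-c2nn(-c3cccc(NC(=O)Nc4cc(C(F)(F)F)cc(C(F)(F)F)c4)c3)cc2-c2ccncc2)ccc1Cl` gives 307 nM in a functional assay on MDA-MB-468 cells (Homo sapiens) for inhibition, read by sulforhodamine B assay, with a stated time of 48 h; a higher number here means a weaker inhibitor of growth, a lower number a stronger inhibitor of growth.
Compound 2 `COc1cc(-c2nn(-c3cccc(NC(=O)c4cccc(C(F)(F)F)c4)c3)cc2-c2ccncc2)ccc1Cl` gives 1320 nM in this assay.
Compound 3 `O=C(Nc1cccc(-n2cc(-c3ccncc3)c(-c3ccc(Cl)c(O)c3)n2)c1)Nc1ccc(Cl)c(Cl)c1` gives 729 nM in this assay.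

Among the three measured compounds, compound 2 holds the highest number in this assay. Its gap to compound 3 is within the usual scatter, so those two cannot be ordered. Its gap to compound 1 is beyond the scatter, and of that pair compound 1 is the stronger inhibitor of growth.

Compound 4 `COc1cc(-c2nn(-c3cccc(NC(=O)Nc4cccc(C(F)(F)F)c4)c3)cc2-c2ccncc2)ccc1Cl` has not yet been measured. It differs from compound 2 in one place: (3-(trifluoromethyl)phenyl)amino in place of 3-(trifluoromethyl)phenyl on a carbonyl carbon. Compound 1 and compound 3 both carry an amino group on that carbonyl carbon, though each also differs from compound 4 elsewhere. Compound 1 shows a number well below that of compound 2, while compound 3 sits within the scatter of compound 2.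

On that basis, the step from compound 2 to compound 4 is expected to lower the number in this assay by a 2.9-fold lower number from compound 2 to compound 4 (0.47 log units; beyond the scatter), a change in the same direction as the gap between compound 2 and compound 1 but of uncertain size. Compound 4 is therefore estimated at 450 nM, with a likely range from 180 nM to 1100 nM.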

Compound 4, concentration for 50% growth inhibition: 598 nM
Compound 4: the middle estimate sits 1.3-fold (0.12 log units) below what was measured; measured number inside the range.
By their numbers in this assay, from the lowest: compounds 1, 4, 3 and 2 (each within the scatter of the next, the first and the last beyond it).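

For the compounds shown here, compound 2 and compound 4 give the first comparison in which the carbonyl carbon's substituent alone differs, and in this assay the change to (3-(trifluoromethyl)phenyl)amino gives a 2.2-fold lower number from compound 2 to compound 4 (0.34 log units; beyond the scatter) as a modest but real gain in growth inhibition. Going by these compounds alone, compound 1 and compound 3 also carry an amino group on that carbonyl carbon, but each differs elsewhere, so only this pair ties the gain to the swap itself, in which a group with 1 hydrogen-bond donor replaces one with 0. At the aromatic carbon of the terminal ring, hydrogen in place of trifluoromethyl gives a 1.9-fold higher number from compound 1 to compound 4 (0.29 log units; within the scatter) and leaves compound 1 and compound 4 unordered, so a second trifluoromethyl shows no separable effect here. The data offer no measurement that would explain why the amino group lowers the number.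

Going by these compounds, it remains open whether the gain depends on the nitrogen and its hydrogen, which a carbamate oxygen or a methylamino group on the same carbonyl carbon would test. Also open, on these data alone, is whether the step holds with a hydroxyl in place of the methoxy group, or with chlorine on the terminal ring in place of trifluoromethyl.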